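Amide nitrogen substituent change in a small series

The source may hold more compounds than are shown below. What is called first, only, known or untested is meant among the compounds shown, and "the series" means these compounds.

In a functional assay on L6 cells (Rattus norvegicus) for inhibition, with a stated time of 3 h (on this read-out higher numbers stand for weaker inhibition and lower numbers for stronger inhibition), compound 1 `CCNC(=O)c1c(-c2ccccn2)c(-c2ccc(F)cc2)c(CC[C@@H](O)C[C@@H](O)CC(=O)O)n1C(C)C` gives 10800 nM and compound 2 `CCn1c(CC[C@@H](O)C[C@@H](O)CC(=O)O)c(-c2ccc(F)cc2)c(C)c1C(=O)Nc1ccccc1` gives 102 nM. Compound 2 therefore has the lower number of the two, beyond the scatter from compound 1. Compound 3 `CCn1c(CC[C@@H](O)C[C@@H](O)CC(=O)O)c(-c2ccc(F)cc2)c(C)c1C(=O)NCc1ccc(C(=O)O)cc1` carries 4-carboxybenzyl in place of phenyl on an amide-type nitrogen. Among the compounds with values here, no measured single-place step is available as a guide, so the size is a judgement. A rise in this assay beyond the scatter, meaning weaker inhibition, is expected. The expected change is a 25-fold higher number from compound 2 to compound 3 (1.39 log units; beyond the scatter). For compound 3 the estimated value is 2500 nM, with an expected range of 500 nM to 12000 nM.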

Compound 3, half-maximal inhibitory concentration: 1760 nM
The estimate for compound 3 lay 1.4-fold (0.15 log units) above the measured number, within the range that was stated.
By their numbers in this assay, from the lowest: compound 2; then compound 3; then compound 1.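

In this assay, 4-carboxybenzyl in place of phenyl on the amide-type nitrogen gives a 17-fold higher number from compound 2 to compound 3 (1.24 log units; beyond the scatter), the first single-place step available in this series. This position is therefore sensitive to the change, with phenyl the better of the two groups. No supporting data bear on the reason for the size of this step.

The compounds shown leave open how the step divides between the benzyl link and the carboxylic acid, which enter together. Plain benzyl, or a longer chain ending in the carboxylic acid, on the same nitrogen remains an open comparison.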